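Working notes: methoxy step from compound 1 to compound 3

A few compounds are considered here, and "the series" means these few. Any claim that something is new, unique, unknown or untested is made for them only; others in the source may bear on it.

Compound 1 `Nc1cccc(/C=C/c2ccccc2)c1` is the reference point of this pair. In a functional assay on HT-29 cells (Homo sapiens) for inhibition, read by MTT assay, with a stated time of 2 days (on this read-out higher numbers stand for weaker inhibition and lower numbers for stronger inhibition), compound 1 gives 12.9 ug/mL, the lowest of the two numbers available. Within the data shown here, its only measured neighbour is compound 2 `Nc1cccc(/C=C/c2cccc(O)c2)c1`, which in this assay gives 43 ug/mL; that step is a 3.3-fold higher number from compound 1 to compound 2 (0.52 log units; beyond the scatter). Compound 3 `COc1ccccc1/C=C/c1cccc(N)c1` has not yet been measured in this assay. It differs from compound 1 by methoxy in place of hydrogen on an aromatic carbon. Among the measured compounds shown here, the only measured step that bears on this change is the one adding a group to compound 1, the hydroxy step to compound 2, and it raised the number modestly. A methoxy is a different group at a different place, so the size carries uncertainty; the expectation is a rise in the same direction, possibly smaller, with a result inside the scatter not excluded. The expected step is a 1.9-fold higher number from compound 1 to compound 3 (0.29 log units; within the scatter) for compound 3. Compound 3 is estimated in this assay at 25 ug/mL, within a range from 10 ug/mL to 60 ug/mL.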

Compound 3, half-maximal inhibitory concentration: 25.3 ug/mL
Beside the measured number, compound 3's estimate is 1.0-fold (0.01 log units) below it; the range from low to high includes it.
By their numbers in this assay, from the lowest: compounds 1, 3 and 2 (each within the scatter of the next, the first and the last beyond it).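

In this assay, methoxy in place of hydrogen on an aromatic carbon, ortho to a group of 9 heavy atoms, gives a 2.0-fold higher number from compound 1 to compound 3 (0.29 log units; within the scatter), so at this position the added group leaves the number inside the usual scatter of compound 1. Among these compounds, this is the first reading at this position, and the only earlier step, a 3.3-fold higher number from compound 1 to compound 2 (0.52 log units; beyond the scatter), involves a different group at a different place. Nothing available bears on the reason for this result.

With hydroxy and methoxy each read at one place only, the contributions of group and place to these two steps cannot be separated. As far as these compounds go, whether a hydroxy, an ethoxy or a carboxylic acid at this same place would stay within the scatter of compound 1 remains open.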